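The source may report more compounds than this note shows. Statements on the series, on what has been measured and on what is new or still open speak of the compounds shown alone.

Compounds measured in an assay on CHO cells for inhibition of adenosine receptor A2b (Homo sapiens), read by a luciferase reporter; on this read-out higher numbers stand for weaker inhibition and lower numbers for stronger inhibition:
compound 1 `N#Cc1cccc(-c2nc(Nc3cccnc3)sc2-n2cncn2)c1`, 86 nM;
compound 2 `N#Cc1cccc(-c2nc(Nc3cccnc3)sc2-n2ccnc2)c1`, 92 nM.

Within the data shown here, compound 2 stands highest of the two numbers in this assay, yet the only measured step, a 1.1-fold higher number from compound 1 to compound 2 (0.03 log units; within the scatter), lies within the scatter, so compound 1 and compound 2 are not separated by the data. Compound 3 `N#Cc1cccc(-c2nc(Nc3cnccn3)sc2-n2ccnc2)c1` differs from compound 2 by pyrazin-2-yl in place of pyridin-3-yl on a nitrogen on an aromatic ring. Among the measured compounds shown here, no measured step touches this position; the single step recorded concerns the azole on the aromatic carbon and is within the scatter, so it carries no information on the amine substituent. With nothing pointing in either direction, no step beyond the scatter is expected for compound 3 in this assay, and the range is widened to reflect the absence of any precedent. Compound 3 is estimated at 100 nM (range 35 nM to 300 nM), which corresponds to an expected step of a 1.1-fold higher number from compound 2 to compound 3 (0.04 log units; within the scatter).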

Compound 3, antagonist equilibrium constant: 7 nM
Compound 3: middle estimate off by 14-fold (1.15 log units), on the high side; measured number below the stated range.
By their numbers in this assay, from the lowest: compound 3; then compounds 1 and 2 (each within the scatter of the next).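

The amine substituent is a sensitive position: in this assay, pyrazin-2-yl in place of pyridin-3-yl on a nitrogen on an aromatic ring gives a 13-fold lower number from compound 2 to compound 3 (1.12 log units; beyond the scatter), whereas the azole change, a 1.1-fold higher number from compound 1 to compound 2 (0.03 log units; within the scatter), gave no readable difference. The entering ring keeps 6 heavy atoms and differs in its count, with 2 hetero atoms and 2 hydrogen-bond acceptors against 1 of each in the ring that leaves, so a change of this size at constant ring size is enough to move the number beyond the scatter. Nothing available explains the step.

Open, on these data alone, is whether the step carries over to the 1H-1,2,4-triazol-1-yl partner of compound 3. Also open, as far as these compounds go, is how pyridin-2-yl, pyrimidin-2-yl or plain phenyl would read at this position on the same core.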